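Changing the Group on the Carbonyl Carbon

The source may hold more compounds than are shown below. What is called first, only, known or untested is meant among the compounds shown, and "the series" means these compounds.

Three compounds have been measured in a functional assay on HeLa cells (Homo sapiens), read by MTT assay, with a stated time of 72 h; on this read-out lower numbers stand for stronger inhibition and higher numbers for weaker inhibition:
Compound 1 `COc1cc(NC(C)CCCNC(=O)NCc2ccncc2)c2ncccc2c1` gives 18000 nM.
Compound 2 `COc1cc(NC(C)CCCNC(=O)NCc2ccccc2)c2ncccc2c1` gives 15000 nM.
Compound 3 `COc1cc(NC(C)CCCNC(=O)N(C2CCCCC2)C2CCCCC2)c2ncccc2c1` gives 23000 nM.

Compound 2 gives the lowest of these three numbers, yet neither of the other two is separated from it by more than the usual scatter. Going by the values given here, the one single-point step among them, a 1.2-fold lower number from compound 1 to compound 2 (0.08 log units; within the scatter), exchanged one aromatic group for another on the chain attached to the amide-type nitrogen and changed nothing beyond the scatter; compound 3, which carries two saturated rings on that nitrogen instead, also sits within the scatter of compound 2.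

Compound 4 `COc1cc(NC(C)CCCNC(=O)n2nnc3ccccc32)c2ncccc2c1` has not yet been measured. It differs from compound 2 in one place: a group of 9 heavy atoms (6 carbon, 3 nitrogen; one five-membered aromatic ring with 3 hetero atoms, one six-membered aromatic ring of carbon only) in place of a group of 8 heavy atoms (7 carbon, 1 nitrogen; one six-membered aromatic ring of carbon only), on a carbonyl carbon. Among the compounds with values here, the only measured step touching this end of the molecule is a 1.2-fold lower number from compound 1 to compound 2 (0.08 log units; within the scatter), and it was flat, while compound 3 with a much larger group there is also flat against compound 2. On this basis the step from compound 2 to compound 4 is expected to be no change at the digits printed from compound 2 to compound 4 (within the scatter), nothing beyond the scatter. Compound 4 is therefore estimated at 15000 nM in this assay, with an expected range from 6000 nM to 40000 nM.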

Compound 4, half-maximal inhibitory concentration: 71000 nM
Compound 4: middle estimate off by 4.7-fold (0.68 log units), on the low side, outside the stated range (above it).
By their numbers in this assay, from the lowest: compounds 2, 1 and 3 (each within the scatter of the next); then compound 4.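

In this assay, going by these compounds alone, the group on the carbonyl carbon proves able to shift the number beyond the scatter, which none of the earlier compounds showed. Replacing benzylamino with the two-ring group of nine heavy atoms gives a 4.7-fold higher number from compound 2 to compound 4 (0.68 log units; beyond the scatter), and the same group in place of the pyridine-bearing group gives a 3.9-fold higher number from compound 1 to compound 4 (0.60 log units; beyond the scatter), both modest steps towards weaker inhibition. Losing the hydrogen-bond donor does not sort these compounds by itself: compound 3 also has no hydrogen on the nitrogen bound to the carbonyl, yet it stays within the scatter of compound 2.

Nothing available explains why this group weakens inhibition. Going by these compounds, whether the weaker inhibition belongs to this particular two-ring group or extends to smaller groups on the carbonyl carbon, such as dimethylamino or methoxy, remains open.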